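The compounds below may be only part of what the source reports. "The series", "measured", "known", "first", "only" and "open" are said of these compounds alone.

In a functional assay on HepG2 cells (Homo sapiens) for inhibition, read by fluorescence and resazurin assay, with a stated time of 72 h (on this read-out lower numbers stand for stronger inhibition and higher numbers for weaker inhibition), compound 1 (`O=C(Nc1ccccc1)Nc1cccc(Nc2nccc(Nc3ccc4cn[nH]c4c3)n2)c1`) gives 8200 nM as its value, compound 2 (`O=C(Nc1ccc(F)cc1)Nc1cccc(Nc2nccc(Nc3ccc4cn[nH]c4c3)n2)c1`) gives 12000 nM and compound 3 (`Cc1ccc(NC(=O)Nc2cccc(Nc3nccc(Nc4ccc5cn[nH]c5c4)n3)c2)cc1`) gives 11000 nM on the same read-out. Compound 3 therefore sits within the usual scatter of both other compounds, and these three numbers cannot be ranked.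

Compound 4 (`Cc1cccc(NC(=O)Nc2cccc(Nc3nccc(Nc4ccc5cn[nH]c5c4)n3)c2)c1`) has the same atoms as compound 3, joined differently: 3-methylphenyl stands in place of 4-methylphenyl on an amide-type nitrogen (3-methylphenyl in place of 4-methylphenyl on an amide-type nitrogen). Among the compounds with values here, no measured compound carries 3-methylphenyl, so this exact change has not been tested.

The closest evidence comes from three small changes on the same phenyl group. Methyl in place of hydrogen gave a 1.3-fold higher number from compound 1 to compound 3 (0.13 log units; within the scatter) and fluoro in place of hydrogen gave a 1.5-fold higher number from compound 1 to compound 2 (0.17 log units; within the scatter) while methyl in place of fluoro gave a 1.1-fold lower number from compound 2 to compound 3 (0.04 log units; within the scatter) on the same read-out. None of these steps goes beyond the scatter, so no step beyond the scatter is expected here either, and no direction can be favoured. The estimated change is a 1.1-fold lower number from compound 3 to compound 4 (0.04 log units; within the scatter) in this assay and would be no real difference. Compound 4 is expected at an estimated 10000 nM with a likely range from 5000 nM to 20000 nM for repeated measurements.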

Compound 4, half-maximal inhibitory concentration: 2800 nM
Beside the measured number, compound 4's estimate is 3.6-fold (0.55 log units) above it, outside the stated range (below it).
By their numbers in this assay, from the lowest: compound 4; then compounds 1, 3 and 2 (each within the scatter of the next).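

Moving the methyl group, so that 3-methylphenyl stands in place of 4-methylphenyl on the amide-type nitrogen, gives a 3.9-fold lower number from compound 3 to compound 4 (0.59 log units; beyond the scatter) in this assay, even though the two compounds have the same atoms. Within the data shown here, this is the first step to go beyond the scatter, and it shows that this part of the molecule can affect the number and that where the methyl sits on the phenyl ring matters. The same group also separates compound 4 from the other two, with a 2.9-fold lower number from compound 1 to compound 4 (0.47 log units; beyond the scatter) and a 4.3-fold lower number from compound 2 to compound 4 (0.63 log units; beyond the scatter), whereas 4-fluorophenyl and 4-methylphenyl stayed within the scatter of plain phenyl, although nothing available explains why this shift lowers the number.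

On these data alone, it remains open whether the lower number belongs to the methyl group itself or would also appear with a fluoro, a methoxy or an amine in the ring place that the methyl occupies in 3-methylphenyl. A longer chain such as ethyl or propyl in that same place is also untested in the compounds shown, so how much room this position allows remains unknown.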